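Arylmethyl in place of methylsulfonyl on the ring amine

A few compounds are considered here, and "the series" means these few. Any claim that something is new, unique, unknown or untested is made for them only; others in the source may bear on it.

Among the compounds with values here, compound 1 `CCCCNc1nc(N)nc2c1CN(S(C)(=O)=O)CC2` stands at the high end of the two numbers so far: in an assay on HEK293 cells for agonist activity at Toll-like receptor 8 (Homo sapiens), read by a luciferase reporter, with a stated time of 6 h (on this read-out higher numbers stand for an effect only at larger amounts of compound and lower numbers for an effect already at smaller amounts), compound 1 gives 9.9 uM. Compound 2 `CCCCNc1nc(N)nc2c1CN(Cc1ccc(C(F)(F)F)cc1)CC2` in this assay gives 0.23 uM, a gap beyond the scatter. Compound 3 `CCCCNc1nc(N)nc2c1CN(Cc1ccccn1)CC2` differs from compound 1 by (pyridin-2-yl)methyl in place of methylsulfonyl on an amine nitrogen in a ring. Within the data shown here, no measured step of this kind exists; the only guide is compound 2, which carries another arylmethyl group at the same place and gives 0.23 uM. The step is expected to be a 17-fold lower number from compound 1 to compound 3 (1.22 log units; beyond the scatter). In this assay compound 3 is estimated at 0.6 uM, within 0.12 uM to 3 uM.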

Compound 3, minimum effective concentration: 0.07 uM
Compound 3: the middle estimate sits 8.6-fold (0.93 log units) above what was measured; the measured number lies below the stated range.
By their numbers in this assay, from the lowest: compound 3; then compound 2; then compound 1.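

At this amine nitrogen in a ring, (pyridin-2-yl)methyl in place of methylsulfonyl gives a 140-fold lower number from compound 1 to compound 3 (2.15 log units; beyond the scatter) in this assay on a shared core. The position therefore accepts an arylmethyl group with a ring nitrogen as well as the one without it: compound 2 gives 0.23 uM and compound 3 gives 0.07 uM on this read-out.

On these data alone, whether an unsubstituted benzyl, a pyridin-4-ylmethyl or a plain alkyl chain at this nitrogen would give similar numbers remains open. Nothing measured here accounts for the size of the step.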